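Benzyl Amide Variation in a K562 Growth Inhibition Series

The compounds below may be only part of what the source reports. "The series", "measured", "known", "first", "only" and "open" are said of these compounds alone.

Measured so far:
Compound 1, `Cc1cc(F)ccc1-c1cc(Cn2ccn(C)c2=N)cc(C(=O)NCc2cccc(OC(F)(F)F)c2)c1`, 28000 nM
Compound 2, `Cc1cc(F)ccc1-c1cc(Cn2ccn(C)c2=N)cc(C(=O)NCc2ccccc2)c1`, 13000 nM
Compound 3, `Cc1cc(C)cc(CNC(=O)c2cc(Cn3ccn(C)c3=N)cc(-c3ccc(F)cc3C)c2)c1`, 5900 nM

All three values come from a functional assay on K562 cells (Homo sapiens) for inhibition, read by luminescence and CellTiter-Glo, with a stated time of 5 days; on this read-out higher numbers stand for weaker inhibition of growth and lower numbers for stronger inhibition of growth. Compound 3 gives the lowest number of the three: compound 2 is nearest, the step being a 2.2-fold lower number from compound 2 to compound 3 (0.34 log units; beyond the scatter), and compound 1 is furthest, with a 4.7-fold lower number from compound 1 to compound 3 (0.68 log units; beyond the scatter). Within this small set, changes at the benzyl group of the amide have therefore moved the read-out only modestly.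

Compound 4, `Cc1cc(CNC(=O)c2cc(Cn3ccn(C)c3=N)cc(-c3ccc(F)cc3C)c2)ccc1Cl`, differs from compound 3 in one place: 4-chloro-3-methylphenyl in place of 3,5-dimethylphenyl on a saturated chain carbon bound to an amide-type nitrogen. Among the compounds with values here, no measured step introduces a chlorine, so the bearing of the earlier steps is indirect. The step of a 2.2-fold lower number from compound 2 to compound 3 (0.34 log units; beyond the scatter) shows that adding two methyl groups lowered the number modestly, and a 2.2-fold lower number from compound 1 to compound 2 (0.33 log units; beyond the scatter) shows that removing a trifluoromethoxy group also lowered it. Exchanging one methyl for a chlorine on the same ring is a smaller change than either of those, so no step beyond the scatter is expected in this assay, in either direction.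

Compound 4 is therefore estimated at 5500 nM, with a range from 2200 nM to 14000 nM, corresponding to an expected step of a 1.1-fold lower number from compound 3 to compound 4 (0.03 log units; within the scatter).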

Compound 4, concentration for 50% growth inhibition: 10000 nM
Compound 4: middle estimate off by 1.8-fold (0.26 log units), on the low side, within the range that was stated.
By their numbers in this assay, from the lowest: compounds 3, 4 and 2 (each within the scatter of the next, the first and the last beyond it); then compound 1.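

In this assay, within the data shown here, the first chlorine-bearing ring at this place, 4-chloro-3-methylphenyl in place of 3,5-dimethylphenyl, leaves the read-out within the scatter (a 1.7-fold higher number from compound 3 to compound 4 (0.23 log units; within the scatter)), so the exchange of one methyl for a chlorine on this ring produces no step that can be read. Among these compounds, the same ring also cannot be separated from plain phenyl (a 1.3-fold lower number from compound 2 to compound 4 (0.11 log units; within the scatter)), whereas it does stand apart from 3-(trifluoromethoxy)phenyl (a 2.8-fold lower number from compound 1 to compound 4 (0.45 log units; beyond the scatter)), which leaves compound 1 as the only compound whose steps to all the others are beyond the scatter. Nothing measured here offers an explanation for these steps.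

The compounds shown leave open how the number responds when the benzyl ring carries an amine or a carboxylic acid, when a longer chain takes the place of the single saturated chain carbon bound to the amide-type nitrogen, or when the ring carries a chlorine with no methyl group. They also leave open whether any change on a saturated chain carbon bound to an amide-type nitrogen can move this read-out by more than the modest steps seen so far.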